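Replacing the pyridyl ring of compound 2 with a methoxyphenyl ring

The compounds below may be only part of what the source reports. "The series", "measured", "known", "first", "only" and "open" are said of these compounds alone.

Compound 1 `O=C(CN1CCN(c2ccccc2)CC1)Nc1nc2ccccc2[nH]1` gave 62.1% in a functional assay, read by spectrophotometry, with a stated time of 30 min, tested at 200 ug/mL; a lower number here means a weaker effect, a higher number a stronger effect of the compound at the concentration tested. Compound 2 `O=C(CN1CCN(c2ccccn2)CC1)Nc1nc2ccccc2[nH]1` gave 76.2%. Compound 3 `COc1ccc(N2CCN(CC(=O)Nc3nc4ccccc4[nH]3)CC2)cc1` gave 63.7%.

Compound 2 stands highest of the three. It lies above compound 1 by a number 14.1 percentage points higher from compound 1 to compound 2 (beyond the scatter), and compound 3 lies below it by a number 12.5 percentage points lower from compound 2 to compound 3 (beyond the scatter); compound 1 and compound 3 differ only by a number 1.6 percentage points higher from compound 1 to compound 3 (within the scatter).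

Compound 4 `COc1ccccc1N1CCN(CC(=O)Nc2nc3ccccc3[nH]2)CC1` has not been measured. It differs from compound 2 as follows: 2-methoxyphenyl in place of pyridin-2-yl on an amine nitrogen in a ring. The change again exchanges the ring with one nitrogen for a carbon-only ring, which in the step from compound 2 to compound 3 cost a number 12.5 percentage points lower from compound 2 to compound 3 (beyond the scatter), while the added methoxy group mattered little in the step from compound 1 to compound 3. A similar drop is therefore expected, a number 13.2 percentage points lower from compound 2 to compound 4 (beyond the scatter). Compound 4 is estimated at 63%, between 52% and 74%.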

Compound 4, a percentage reported as activity, at one concentration (the size of the read-out at that concentration, not a potency): 64.5%
Compound 4: the middle estimate sits 1.5 percentage points below what was measured; measured number inside the range.
By their numbers in this assay, from the lowest: compounds 1, 3 and 4 (each within the scatter of the next); then compound 2.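

In this assay, the place of the methoxy group on the carbon-only ring made no difference that can be read: 2-methoxyphenyl in place of 4-methoxyphenyl gave a step within the scatter (a number 0.8 percentage points higher from compound 3 to compound 4 (within the scatter)), as did methoxy in place of hydrogen (a number 2.4 percentage points higher from compound 1 to compound 4 (within the scatter)). The loss from pyridin-2-yl now appears with a second methoxyphenyl group (a number 11.7 percentage points lower from compound 2 to compound 4 (beyond the scatter)), so among these four compounds only compound 2 stands apart. Nothing measured here accounts for that gap. Going by these compounds, whether a pyridin-3-yl ring, or an amine or carboxylic acid on the carbon-only ring, would match compound 2 remains open.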